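Replacing thiophen-2-yl with 4-iodophenyl on compound 1

The source may hold more compounds than are shown below. What is called first, only, known or untested is meant among the compounds shown, and "the series" means these compounds.

Going by the values given here, compound 1 `O=C(/C=C/c1ccc2c(c1)B(O)OC2)c1cccs1` gives 10400 nM in a functional assay on SK-OV-3 cells (Homo sapiens) for cytotoxicity, read by MTT assay, with a stated time of 48 h (a higher number here means a weaker inhibitor, a lower number a stronger inhibitor), the second highest of the three numbers measured so far. Compound 2 `Cn1cccc1C(=O)/C=C/c1ccc2c(c1)B(O)OC2` gives 93600 nM in this assay, and compound 3 `O=C(/C=C/c1ccc2c(c1)B(O)OC2)c1ccc(F)cc1` gives 1400 nM. The change to compound 4 `O=C(/C=C/c1ccc2c(c1)B(O)OC2)c1ccc(I)cc1` is 4-iodophenyl in place of thiophen-2-yl on a carbonyl carbon. The step that bears on it most is a 7.4-fold lower number from compound 1 to compound 3 (0.87 log units; beyond the scatter), where 4-fluorophenyl took the place of the same group. The move the other way, a 9.0-fold higher number from compound 1 to compound 2 (0.95 log units; beyond the scatter), shows that the group on the carbonyl carbon shifts the number a good deal in either direction. Among the compounds with values here, a downward step of similar size is therefore expected for compound 4, a 5.2-fold lower number from compound 1 to compound 4 (0.72 log units; beyond the scatter), although no iodine-bearing compound has been measured here. Compound 4 is estimated at 2000 nM, within a range of 600 nM to 7000 nM.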

Compound 4, half-maximal inhibitory concentration: 4200 nM
The estimate for compound 4 lay 2.1-fold (0.32 log units) below the measured number; the range from low to high includes it.
By their numbers in this assay, from the lowest: compound 3; then compound 4; then compound 1; then compound 2.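

In this assay, 4-iodophenyl on the carbonyl carbon also gives a lower number than thiophen-2-yl, with a 2.5-fold lower number from compound 1 to compound 4 (0.39 log units; beyond the scatter), so the drop seen with 4-fluorophenyl is not confined to that one group. The halogen still matters, since iodo in place of fluoro gives a 3.0-fold higher number from compound 3 to compound 4 (0.48 log units; beyond the scatter). The gain over the methylpyrrole compound remains large, at a 22-fold lower number from compound 2 to compound 4 (1.35 log units; beyond the scatter).

Nothing available here explains these shifts. Also open, going by these compounds, is how 4-chlorophenyl or 4-aminophenyl would behave on the same carbonyl carbon.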